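From 2-Chlorophenyl to 2-Methoxyphenyl

This account rests on a few compounds, and the source may have more. Where it says the series, first, only, none or still open, it means among the compounds named here.

In a functional assay on HL-60 cells (Homo sapiens) for inhibition, read by CCK-8 assay, with a stated time of 48 h, tested at 20 uM (on this read-out lower numbers stand for less inhibition of growth and higher numbers for more inhibition of growth at the one concentration tested), compound 1 `Cc1ccc(S(=O)(=O)Oc2cccc(/C=C(\C#N)C(=O)Nc3nnc(-c4ccccc4)s3)c2)cc1` gives 63% and compound 2 `Cc1ccc(S(=O)(=O)Oc2cccc(/C=C(\C#N)C(=O)Nc3nnc(-c4ccccc4Cl)s3)c2)cc1` gives 67%, so compound 2 stands within the scatter of compound 1. Compound 3 `COc1ccccc1-c1nnc(NC(=O)/C(C#N)=C/c2cccc(OS(=O)(=O)c3ccc(C)cc3)c2)s1` carries methoxy in place of chloro on an aromatic carbon, ortho to a large group: methoxy in place of chloro on an aromatic carbon. Going by the values given here, the one measured step bearing on this change is a number 4 percentage points higher from compound 1 to compound 2 (within the scatter), and no measurement yet covers methoxy. In this assay the expected change is therefore no more than scatter, an estimated a number 4 percentage points lower from compound 2 to compound 3 (within the scatter). For compound 3 the estimated value is 63%, with an expected range of 49% to 77%.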

Compound 3, percent growth inhibition at one concentration: 73%
Beside the measured number, compound 3's estimate is 10 percentage points below it, within the range that was stated.
By their numbers in this assay, from the lowest: compounds 1, 2 and 3 (each within the scatter of the next).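

In this assay the change from 2-chlorophenyl to 2-methoxyphenyl gives a number 6 percentage points higher from compound 2 to compound 3 (within the scatter) and methoxy in place of hydrogen on the same aromatic carbon gives a number 10 percentage points higher from compound 1 to compound 3 (within the scatter). This position, ortho to a large group, has now carried hydrogen, chloro and methoxy, and all three numbers lie within the scatter of one another. Nothing available explains the result. On these data alone, whether an amine, a carboxylic acid or a longer chain such as ethoxy here would move the number beyond the scatter remains open, as does whether these three compounds would separate at another concentration.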